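Propyl chain in place of dimethoxypropyl on compound 1

The source may report more compounds than this note shows. Statements on the series, on what has been measured and on what is new or still open speak of the compounds shown alone.

Three compounds have numbers in a functional assay on HCT-116 cells (Homo sapiens) for antiproliferative activity, read by CCK-8 assay, with a stated time of 72 h, tested at 8 uM; on this read-out higher numbers stand for a stronger effect at the one concentration tested and lower numbers for a weaker effect. Compound 1 `COC(CCn1cnc2c(NCc3ccc(C(=O)Nc4ccccc4N)cc3)nc(Cl)nc21)OC` gives 11.9%, the lowest of the three numbers shown. Compound 3 `Nc1ccccc1NC(=O)/C=C/c1ccc(Cn2cnc3c(NCc4ccccc4)nc(Cl)nc32)cc1` gives 17.4%, which lies within the scatter of compound 1. Compound 2 `CCCCn1cnc2c(Nc3cccc(Cl)c3)nc(NCOCc3ccc(C(=O)Nc4ccccc4N)cc3)nc21` gives 71.9%, far above compound 1 and beyond the scatter. Compound 4 `CCCn1cnc2c(NCc3ccc(C(=O)Nc4ccccc4N)cc3)nc(Cl)nc21` differs from compound 1 in one place: methyl in place of dimethoxymethyl on a saturated chain carbon, two bonds along the chain from an aromatic nitrogen. Going by the values given here, no measured pair shows this change, so its size is not known from the data, and nothing here shows what the dimethoxymethyl group contributes. With compound 1 at 11.9%, the step of a number 3.1 percentage points higher from compound 1 to compound 4 (within the scatter) is expected to stay within the scatter, in no clear direction. Compound 4 is estimated at 15%, between 4% and 32%.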

Compound 4, a percentage reported as inhibition, at one concentration (the size of the read-out at that concentration, not a potency): 29.6%
Compound 4: the middle estimate sits 14.6 percentage points below what was measured, within the range that was stated.
By their numbers in this assay, from the lowest: compounds 1 and 3 (each within the scatter of the next); then compound 4; then compound 2.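

In this assay going from 3,3-dimethoxypropyl to propyl gives a number 17.7 percentage points higher from compound 1 to compound 4 (beyond the scatter) and shows that the dimethoxymethyl group is not required at this position for the effect at the one concentration tested. Going by these compounds alone, this is the first comparison that differs in one place, and it shows that this chain end can move the number while the rest of compound 1 stays fixed. Nothing measured here explains the step.

Open, on these data alone, is whether a pentyl chain, or an amine or carboxylic acid at the chain end, would move the number further. Also open, as far as these compounds go, is whether the same step would appear on a different core.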